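Amide Aryl Swap on a Sulfonamide Series

A few compounds are considered here, and "the series" means these few. Any claim that something is new, unique, unknown or untested is made for them only; others in the source may bear on it.

Measured compounds:
compound 1, `O=C(NCc1ccc(CNS(=O)(=O)c2ccccc2F)cc1)c1cccnc1`, 100 nM
compound 2, `O=C(NCc1ccc(CNS(=O)(=O)c2cccc3ccccc23)cc1)c1cccnc1`, 1000 nM
compound 3, `Cc1ccccc1S(=O)(=O)NCc1ccc(CNC(=O)c2cccnc2)cc1`, 1000 nM

In an assay on MDA-MB-231 cells for displacement of a labelled ligand from C-X-C chemokine receptor type 4 (Homo sapiens), read by fluorescence and microscopy, with stated times of 10 min and 30 min (a higher number here means that more compound is needed for the effect, a lower number that less compound is needed), compound 1 stands lowest of the three numbers. The step of a 10-fold higher number from compound 1 to compound 2 (1.00 log units; beyond the scatter) and the step of a 10-fold higher number from compound 1 to compound 3 (1.00 log units; beyond the scatter) both move away from it by the same amount, while the step of no change at the digits printed from compound 2 to compound 3 (within the scatter) shows nothing beyond the scatter between the other two. Every measured change so far sits on the sulfonyl sulfur side of the shared core.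

Compound 4, `Cc1ccccc1C(=O)NCc1ccc(CNS(=O)(=O)c2ccccc2F)cc1`, keeps the 2-fluorophenyl sulfonyl of compound 1 and changes the other end instead: 2-methylphenyl in place of pyridin-3-yl on a carbonyl carbon. For the measured compounds named here, no measured step touches the carbonyl carbon, so the three steps above do not bear on this change directly; they show only that the series is sensitive to the aryl group on one end. Without a comparable step the expectation is of a change near the scatter, leaning toward a somewhat higher number.

Compound 4 is therefore estimated at 250 nM, with a range of 60 nM to 1500 nM, meaning an expected step of a 2.5-fold higher number from compound 1 to compound 4 (0.40 log units; beyond the scatter) in this assay.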

Compound 4, effective concentration (reported as EC, without a stated level of effect): 1000 nM
Compound 4: middle estimate off by 4.0-fold (0.60 log units), on the low side, and the stated range covers the measured number.
By their numbers in this assay, from the lowest: compound 1; then compounds 2, 3 and 4 (each within the scatter of the next).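

In this assay, the carbonyl end of the molecule proves responsive too: with the 2-fluorophenyl sulfonyl group held constant, 2-methylphenyl in place of pyridin-3-yl on a carbonyl carbon gives a 10-fold higher number from compound 1 to compound 4 (1.00 log units; beyond the scatter), a step of the same printed size as the sulfonyl-side change in a 10-fold higher number from compound 1 to compound 3 (1.00 log units; beyond the scatter). Compound 1 thus keeps the lowest number in the set, and so far every single change away from it, at either end of the shared core, has raised the number, though the change at the carbonyl carbon rests on compound 4 alone. For the compounds shown here, the swap removes a ring nitrogen, with its one hydrogen-bond acceptor, and brings in a ring of carbon only that carries a methyl group, but nothing available explains why the number moves.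

The compounds shown cannot say whether the step follows the loss of the ring nitrogen or the arrival of the methyl group, a question that plain phenyl on the carbonyl carbon would help to separate. They also leave open whether the nitrogen's place in the ring matters, as pyridin-2-yl or pyridin-4-yl at this position would show.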